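A Methyl-to-Cyclopropyl Swap on a Glutamate Receptor Modulator

The source may report more compounds than this note shows. Statements on the series, on what has been measured and on what is new or still open speak of the compounds shown alone.

Compound 1, `Cn1sc2cc(OCc3cccc(-c4ccc(Cl)c(C(=O)O)c4)c3)ccc2c1=O`, was characterised in an assay on HEK293 cells for positive allosteric modulation of metabotropic glutamate receptor 2 (Rattus norvegicus), read by thallium flux (a higher number here means a larger maximal response, a lower number a smaller maximal response), where compound 1 gives 74.7%. This is the lower of the two numbers available, the other belonging to compound 2, `O=C(O)c1cc(-c2cccc(COc3ccc4c(=O)n(C5CCCC5)sc4c3)c2)ccc1F`, which in this assay gives 83.4%; the gap between compound 1 and compound 2 lies within the scatter, and the two structures differ in more than one place, so nothing is read from the comparison beyond the values themselves.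

Compound 3, `O=C(O)c1cc(-c2cccc(COc3ccc4c(=O)n(C5CC5)sc4c3)c2)ccc1Cl`, has not yet been tested. It differs from compound 1 by cyclopropyl in place of methyl on an aromatic nitrogen. Within the data shown here, no measured pair isolates this change. The expected step in this assay from compound 1 to compound 3 is a number 4.3 percentage points higher from compound 1 to compound 3 (within the scatter), a move no larger than the scatter and in no confident direction. Compound 3 is expected to reach 79%, with a range from 64% to 94%.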

Compound 3, largest response reached (reported as percent of maximum), in percent of the reference or control that the assay uses: 70.6%
Compound 3: middle estimate off by 8.4 percentage points, on the high side; the range from low to high includes it.
By their numbers in this assay, from the lowest: compounds 3, 1 and 2 (each within the scatter of the next, the first and the last beyond it).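

In this assay, among these compounds, cyclopropyl in place of methyl on an aromatic nitrogen gives a number 4.1 percentage points lower from compound 1 to compound 3 (within the scatter), the first measured step that isolates this change. At this position next to the ring sulfur, the two extra heavy atoms and the three-membered ring leave compound 3 indistinguishable from compound 1 in maximal response, so the pair shows no effect of the swap that exceeds the scatter. No measurement shown here offers an explanation for this result.

As far as these compounds go, whether an ethyl group or a longer chain ending in an amine on the same nitrogen would also stay within the scatter remains open. This single pair also cannot show whether the swap would give a similar step on another compound of the series.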